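The source may hold more compounds than are shown below. What is called first, only, known or untested is meant among the compounds shown, and "the series" means these compounds.

Measured compounds:
compound 1 `CN1CCN(CC(=O)Nc2ccc(-c3nc(-c4ccccc4)c(-c4ccccc4)n3C)cc2)CC1`: 28.6%
compound 2 `Cn1c(-c2ccc(NC(=O)CN3CCN(c4ccccc4)CC3)cc2)nc(-c2ccccc2)c1-c1ccccc1`: 37.7%

Among the measured compounds shown here, in a functional assay on MCF7 cells (Homo sapiens) for cytotoxicity, read by MTT assay, with a stated time of 24 h, tested at 6.4 ug/mL (a higher number here means a stronger effect of the compound at the concentration tested, a lower number a weaker effect), compound 2 gives 37.7%; of the two numbers known this is the one that reads higher, but the step of a number 9.1 percentage points higher from compound 1 to compound 2 (within the scatter) lies within the scatter, so compound 1 with 28.6% cannot be separated from it on this read-out. Compound 3 `COc1ccc(CN2CCN(CC(=O)Nc3ccc(-c4nc(-c5ccccc5)c(-c5ccccc5)n4C)cc3)CC2)cc1` has not yet been measured. It differs from compound 2 in one place: 4-methoxybenzyl in place of phenyl on an amine nitrogen in a ring. For the measured compounds named here, the only step known, a number 9.1 percentage points higher from compound 1 to compound 2 (within the scatter), also exchanged the group on that same amine nitrogen in a ring and did not move the number beyond the scatter. Going by the values given here, that is the sole piece of evidence bearing on the new step, and it suggests that exchanging the group on that amine nitrogen in a ring has so far left the read-out in this assay largely unchanged, though a single step is thin ground for a pattern. Compound 3 is therefore expected to give a number close to that of compound 2, with a step of a number 2.7 percentage points lower from compound 2 to compound 3 (within the scatter) that stays within the scatter. Compound 3 is estimated at 35%, within a range from 20% to 50%.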

Compound 3, a percentage reported as activity, at one concentration (the size of the read-out at that concentration, not a potency): 29%
For compound 3 the middle estimate is 6 percentage points above the measured one, and the stated range covers the measured number.
By their numbers in this assay, from the lowest: compounds 1, 3 and 2 (each within the scatter of the next).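

In this assay, the amine nitrogen in the ring has now carried three different groups, and exchanging phenyl for 4-methoxybenzyl gives a number 8.7 percentage points lower from compound 2 to compound 3 (within the scatter) while the comparison with the methyl group gives a number 0.4 percentage points higher from compound 1 to compound 3 (within the scatter) on the same read-out. Among the compounds shown here, the single earlier step therefore becomes a set of three compounds that this read-out cannot separate, even though the entering group brings 9 heavy atoms, including an oxygen, and places a saturated chain carbon on the ring nitrogen, and none of compounds 1, 2 and 3 goes against this pattern. Nothing measured here offers an explanation for this flat result.

On these data alone, how hydrogen, an acetyl group or a chain ending in a carboxylic acid on that nitrogen would read in this assay remains open, as does whether a benzyl group without the methoxy would read any differently from 4-methoxybenzyl. Since all three numbers come from a single concentration, the compounds shown also leave open whether they would differ in potency, and whether changes elsewhere on the shared core would move the read-out beyond the scatter.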